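The source may hold more compounds than are shown below. What is called first, only, known or untested is meant among the compounds shown, and "the series" means these compounds.

Two compounds carry measurements in an assay on cells for inhibition of cytochrome P450 11B2, mitochondrial (Homo sapiens); a higher number here means a weaker inhibitor, a lower number a stronger inhibitor. Compound 1 `C[C@@H](c1ccc(Cl)cc1)N1Cc2cncn2C(CC2(C)COC2)S1(=O)=O` is the more informative of the two: in this assay compound 1 gives 7.8 nM, a low number and therefore a strong inhibitor. Compound 2 `CC(C)CC1n2cncc2CN(C2CC2)S1(=O)=O` differs from it in several places at once. In this assay compound 2 gives > 1000 nM, which is a limit of the assay rather than a number (the limit of > 1000 nM in this assay, at which 1 of the 2 values shown sits). Within the data shown here, of the values shown, compound 1 thus holds the only real figure, and no step between two measured compounds that differ in a single place is available to calibrate the effect of a single change.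

Compound 3 `COC(C)(C)CC1n2cncc2CN([C@@H](C)c2ccc(Cl)cc2)S1(=O)=O` differs from compound 1 in one place: 1-methoxy-1-methylethyl in place of 3-methyloxetan-3-yl on a saturated chain carbon bound to a saturated ring carbon. The comparison shows that the leaving and entering groups match in size and in hydrogen-bond acceptors, the only difference being that the ring is opened into a chain. Without a measured step of this kind, the expectation is a small move, if any, toward weaker inhibition, close to the usual scatter. Compound 3 is therefore expected to give about 12 nM in this assay, within a range from 4 nM to 40 nM. That amounts to an expected step of a 1.5-fold higher number from compound 1 to compound 3 (0.19 log units; within the scatter).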

Compound 3, half-maximal inhibitory concentration: 0.9 nM
Beside the measured number, compound 3's estimate is 13-fold (1.12 log units) above it, and the stated range ends above it.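

With this result, the group on this saturated chain carbon has its first measured single-place step in this assay: replacing 3-methyloxetan-3-yl with 1-methoxy-1-methylethyl gives an 8.7-fold lower number from compound 1 to compound 3 (0.94 log units; beyond the scatter). The two groups have the same counts of heavy atoms and hydrogen-bond acceptors and differ in that one has a ring and the other has none, so this position can respond clearly to a change that leaves those counts untouched, with a step beyond the usual scatter. Nothing measured here explains why the open chain gives the lower number.

The compounds shown leave open whether the oxygen of the chain matters at all, a question that a tert-butyl group, a 1-hydroxy-1-methylethyl group or a 1-ethoxy-1-methylethyl group in the same place could help to answer. Going by these compounds, this is also a single pair of compounds with the rest of the structure held constant, so it remains unknown whether the same replacement would give a step of similar size on a different core or with a different group elsewhere in the molecule.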